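Swapping Methoxy for Nitro: Expected Growth Inhibition

A few compounds are considered here, and "the series" means these few. Any claim that something is new, unique, unknown or untested is made for them only; others in the source may bear on it.

Measured so far:
compound 1 `COc1ccc(C(=O)/C=C/c2ccc(OCc3cn(Cc4ccc(Br)cc4)nn3)cc2)cc1`, 53%
compound 2 `COc1ccc(C(=O)/C=C/c2ccc(OCc3cn(Cc4cccc(F)c4)nn3)cc2)cc1`, 41%

Both were tested in a functional assay on MCF7 cells (Homo sapiens) for inhibition, read by MTT assay, with a stated time of 48 h, tested at 10 uM; on this read-out lower numbers stand for less inhibition of growth and higher numbers for more inhibition of growth at the one concentration tested. Compound 2 stands lowest of the two numbers; its nearest neighbour is compound 1, and the step of a number 12 percentage points lower from compound 1 to compound 2 (beyond the scatter) lies beyond the scatter. Compound 3 `O=C(/C=C/c1ccc(OCc2cn(Cc3cccc(F)c3)nn2)cc1)c1ccc([N+](=O)[O-])cc1` is compound 2 with one change: nitro in place of methoxy on an aromatic carbon. Among the measured compounds shown here, no measured step bears on this change: the only step recorded alters the group on the saturated chain carbon bound to an aromatic nitrogen, not the methoxy. With nothing to guide direction, no step beyond the scatter is expected. The estimate for compound 3 is therefore 45%, within a range from 25% to 65%. The expected step is a number 4 percentage points higher from compound 2 to compound 3 (within the scatter).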

Compound 3, percent growth inhibition at one concentration: 30%
For compound 3 the middle estimate is 15 percentage points above the measured one; the measured number falls inside the stated range.
By their numbers in this assay, from the lowest: compound 3; then compound 2; then compound 1.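

The earlier compounds shown here varied only the group on the saturated chain carbon, while here the change sits on the aromatic carbon that carries the methoxy. In this assay, nitro in place of methoxy gives a number 11 percentage points lower from compound 2 to compound 3 (beyond the scatter) and lies beyond the usual scatter, so this position also affects growth inhibition. Nothing available here explains this drop. Still open, going by these compounds, is how an amine or a carboxylic acid on this aromatic carbon would read, and whether the same step appears when the 4-bromophenyl group of compound 1 replaces the 3-fluorophenyl group.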